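Methylating the phenol of compound 2: a methoxy analogue

A few compounds are considered here, and "the series" means these few. Any claim that something is new, unique, unknown or untested is made for them only; others in the source may bear on it.

In a functional assay on SF-539 cells (Homo sapiens) for inhibition, read by sulforhodamine B assay, with a stated time of 48 h, tested at 10 uM (a lower number here means a stronger effect, a higher number a weaker effect of the compound at the concentration tested), compound 2 `O=C(Nc1cccc(-n2cc(-c3ccncc3)c(-c3cc(O)cc(Cl)c3)n2)c1)Nc1ccc(Cl)c(C(F)(F)F)c1` gives 32.6%, the second highest of the three numbers recorded: compound 1 `COc1cc(Cl)cc(-c2nn(-c3cccc(NC(=O)c4ccc(Cl)c(Cl)c4)c3)cc2-c2ccncc2)c1` gives 74.5%, and compound 3 `O=C(Nc1cccc(-n2cc(-c3ccncc3)c(-c3cc(O)cc(Cl)c3)n2)c1)Nc1ccc(Cl)c(Cl)c1` gives -29%. Among the compounds with values here, the only step measured, a number 61.6 percentage points lower from compound 2 to compound 3 (beyond the scatter), concerns a different part of the molecule and does not bear on the change now considered. Compound 4 `COc1cc(Cl)cc(-c2nn(-c3cccc(NC(=O)Nc4ccc(Cl)c(C(F)(F)F)c4)c3)cc2-c2ccncc2)c1` differs from compound 2 by methyl in place of hydrogen on an oxygen on an aromatic ring. Compound 1, which also carries the methoxy group but a different amide, gives 74.5%, which is the only hint available. A modest weakening is therefore expected, with the step estimated as a number 12.4 percentage points higher from compound 2 to compound 4 (beyond the scatter), and compound 4 is estimated at 45%, between 10% and 80%.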

Compound 4, a percentage reported as activity, at one concentration (the size of the read-out at that concentration, not a potency): -1.17%
Compound 4: middle estimate off by 46.2 percentage points, on the high side; measured number outside the range, below it.
By their numbers in this assay, from the lowest: compound 3; then compound 4; then compound 2; then compound 1.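

Methoxy in place of hydroxy strengthens the effect, with a number 33.8 percentage points lower from compound 2 to compound 4 (beyond the scatter) in this assay, so a free hydroxy at this position is not needed for activity. The weak reading of compound 1 therefore cannot be attributed to the methoxy group: with methoxy held constant, (4-chloro-3-(trifluoromethyl)phenyl)amino in place of 3,4-dichlorophenyl on the carbonyl carbon gives a number 75.7 percentage points lower from compound 1 to compound 4 (beyond the scatter). Nothing at hand explains either shift. Still open, going by these compounds, is whether an ethoxy or an amine at this position would keep the effect, and whether methoxy would act likewise in compound 3.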